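Replacing the tetrazolyl cyclohexyl group of compound 3

The compounds below may be only part of what the source reports. "The series", "measured", "known", "first", "only" and "open" are said of these compounds alone.

Three related compounds share one core and differ in the group on a carbonyl carbon. In an ADME assay on microsomes from liver (Mus musculus) for metabolic stability, with a stated time of 10 min (on this read-out higher numbers stand for a more stable compound and lower numbers for a less stable compound), the entry for compound 1 (`CC[C@]1(C(=O)O)CC[C@H](C(=O)N2CC[C@](c3ccc(C(F)(C(F)(F)F)C(F)(F)F)cc3)(S(=O)(=O)c3ccc(F)cc3)C2)CC1`) reads "not determined" (no result reported) and offers nothing to compare. Compound 2 (`C[C@]1(C(=O)N2CC[C@](c3ccc(C(F)(C(F)(F)F)C(F)(F)F)cc3)(S(=O)(=O)c3ccc(F)cc3)C2)CC[C@H](C(=O)O)CC1`) gives 95% in this assay while compound 3 (`O=C([C@H]1CC[C@H](c2nnn[nH]2)CC1)N1CC[C@](c2ccc(C(F)(C(F)(F)F)C(F)(F)F)cc2)(S(=O)(=O)c2ccc(F)cc2)C1`) gives 73% as the lower of the two available numbers.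

Compound 4 (`O=C(N1CC[C@](c2ccc(C(F)(C(F)(F)F)C(F)(F)F)cc2)(S(=O)(=O)c2ccc(F)cc2)C1)C1(F)CCS(=O)(=O)CC1`) has not been measured yet. It keeps the core but carries 4-fluoro-1,1-dioxothian-4-yl in place of the 4-(1H-tetrazol-5-yl)cyclohexyl of compound 3, and the change can be counted as 4-fluoro-1,1-dioxothian-4-yl in place of 4-(1H-tetrazol-5-yl)cyclohexyl on a carbonyl carbon on the same carbonyl carbon.

Going by the values given here, only one measured step bears on this swap. It is a number 22 percentage points lower from compound 2 to compound 3 (beyond the scatter) and it also exchanges the group on that carbonyl carbon. Among the compounds with values here, that modest step shows that the read-out can respond to a change at this place, but no measured compound carries the new group, so its direction cannot simply be carried over. A small rise is the best guess, and it may well stay inside the usual scatter. The expected outcome is a number 7 percentage points higher from compound 3 to compound 4 (within the scatter). Nothing in the data so far argues for a larger move. Compound 4 is estimated at 80% with an expected range from 60% to 95% in this assay once it is measured.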

Compound 4, percent of the compound remaining: 90%
Compound 4: middle estimate off by 10 percentage points, on the low side; the range from low to high includes it.
By their numbers in this assay, from the lowest: compound 3; then compounds 4 and 2 (each within the scatter of the next).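

Putting 4-fluoro-1,1-dioxothian-4-yl in place of 4-(1H-tetrazol-5-yl)cyclohexyl on the carbonyl carbon gives a number 17 percentage points higher from compound 3 to compound 4 (beyond the scatter) in this assay, so a change at this place can raise the number as well as lower it, whereas the earlier step showed only a fall. The comparison with the carboxylic acid gives a number 5 percentage points lower from compound 2 to compound 4 (within the scatter), which shows that, among these compounds, a high number does not require the 4-carboxy-1-methylcyclohexyl group: a six-membered ring with one sulfur atom, no hydrogen-bond donors and no carboxy group serves as well, while the tetrazole-bearing compound 3 stands apart from both. Nothing measured here explains why the number moves with these groups.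

The new group differs from the old ones in several ways at once, so the compounds shown cannot separate the part played by the fluorine from that of the ring with its two oxygens on sulfur. A plain 1,1-dioxothian-4-yl group without the fluorine, or an amine at the same ring carbon in its place, would be needed to tell these parts apart.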